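A few compounds are considered here, and "the series" means these few. Any claim that something is new, unique, unknown or untested is made for them only; others in the source may bear on it.

Compound 1, `CS(=O)(=O)c1ccc(-c2cnc3[nH]cc(-c4nnc(-c5ccncc5)o4)c(=O)c3c2)cc1`, was tested in a functional assay on HeLa cells (Homo sapiens) for inhibition, read by MTT assay, with a stated time of 24 h, tested at 5 uM (on this read-out higher numbers stand for more inhibition of growth at the one concentration tested and lower numbers for less inhibition of growth), where compound 1 gives 7.08%. Two close relatives have been measured alongside it. Compound 2, `CS(=O)(=O)c1ccc(-c2cnc3[nH]cc(-c4nnc(-c5ccccc5)o4)c(=O)c3c2)cc1`, gives 8.58% in this assay, and compound 3, `Cc1ccc(-c2nnc(-c3c[nH]c4ncc(-c5ccc(S(C)(=O)=O)cc5)cc4c3=O)o2)cc1`, gives 10.5%. Compound 1 thus has the smallest of the three numbers, yet neither relative is truly set apart from it: the change is a number 1.5 percentage points higher from compound 1 to compound 2 (within the scatter), and a number 3.4 percentage points higher from compound 1 to compound 3 (within the scatter). Between the two relatives themselves the difference is a number 1.9 percentage points higher from compound 2 to compound 3 (within the scatter), again within the scatter.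

Compound 4, `Cc1cccc(-c2nnc(-c3c[nH]c4ncc(-c5ccc(S(C)(=O)=O)cc5)cc4c3=O)o2)c1`, has not been measured. It differs from compound 1 in one place: 3-methylphenyl in place of pyridin-4-yl on an aromatic carbon. The two steps from compound 1 to compound 2 and from compound 1 to compound 3 bear on this change most directly, as each also replaces pyridin-4-yl with a carbon-only ring, and both stayed within the scatter; the step from compound 2 to compound 3, methyl in place of hydrogen, stayed within it too. No step beyond the scatter is therefore expected in this assay, in either direction, and the expected step is a number 2.9 percentage points higher from compound 1 to compound 4 (within the scatter). Compound 4 is estimated to give about 10% in this assay, with a likely range from 2% to 18%.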

Compound 4, percent growth inhibition at one concentration: 1.49%
Compound 4: the middle estimate sits 8.5 percentage points above what was measured, outside the stated range (below it).
By their numbers in this assay, from the lowest: compounds 4, 1, 2 and 3 (each within the scatter of the next).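

The new compound tests something the earlier ones could not: where the methyl sits on the phenyl ring. Shifting it from the 4-methylphenyl of compound 3 to the 3-methylphenyl of compound 4 gives a step that stays inside the usual scatter of this assay (a number 9 percentage points lower from compound 3 to compound 4 (within the scatter)), so these data cannot separate the two placements. The other two comparisons read the same way, for the methyl added to the plain phenyl (a number 7.1 percentage points lower from compound 2 to compound 4 (within the scatter)) and for the swap of pyridin-4-yl for 3-methylphenyl (a number 5.6 percentage points lower from compound 1 to compound 4 (within the scatter)), which means that the ring nitrogen, the methyl and the methyl's location have so far produced no step beyond the scatter at this carbon of the five-membered ring, and nothing available here bears on why the numbers fall as they do.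

As far as these compounds go, what stays open is whether a group of a different kind on this ring, such as an amine or a carboxylic acid, would produce a step beyond the scatter. The same question applies to a longer chain, such as a butyl group, in place of the ring.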